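The source may report more compounds than this note shows. Statements on the series, on what has been measured and on what is new or still open speak of the compounds shown alone.

Measured compounds:
Compound 1, `CC(C)Nc1nc(Nc2ccc(C#N)cc2)nc(Oc2ccc3cc(Br)ccc3c2Br)n1`: in an ADME assay on MT4 cells (Homo sapiens) for cytotoxicity, read by MTT assay, with a stated time of 4 days (on this read-out lower numbers stand for higher toxicity in this test and higher numbers for lower toxicity in this test), compound 1 gives >= 209000 nM, which is a limit of the assay and not a number.
Compound 2, `CC(C)Nc1nc(Nc2ccc(C#N)cc2)nc(Oc2ccc3ccccc3c2Br)n1`: in this assay compound 2 gives 41500 nM.

Among the compounds with values here, compound 2 therefore holds the only number in this assay; the other value shown sits at the limit of >= 209000 nM in this assay, at which 1 of the 2 values shown sits. Within the data shown here, the one measured step between these two compounds, an at least 5.0-fold lower number from compound 1 to compound 2 (0.70 log units; beyond the scatter), came with hydrogen in place of bromo on an aromatic carbon, and it is at least modest in size.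

Compound 3, `CCCNc1nc(Nc2ccc(C#N)cc2)nc(Oc2ccc3ccccc3c2Br)n1`, differs from compound 2 at a different part of the molecule: propyl in place of isopropyl on a nitrogen on an aromatic ring. Among the measured compounds shown here, neither measured compound varies at this nitrogen, so the single measured step, which concerns the bromo on the aromatic ring, offers no direct guide to this change. Both groups are chains of the same size, rearranged, and nothing in the measured data points to a shift in either direction. Compound 3 is therefore expected to come out close to compound 2, with a step of no change at the digits printed from compound 2 to compound 3 (within the scatter) that stays within the scatter. The estimate for compound 3 in this assay is 41500 nM, with a range from 15000 nM to 115000 nM.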

Compound 3, half-maximal cytotoxic concentration: > 263000 nM
Compound 3 was reported as a limit; the forecaster's own chance of this, stated with the estimate: 10%; middle value at least 6.3-fold (0.80 log units) from the limit.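

In this assay, the earlier step concerned only the bromo on the aromatic ring; this one shows that the group on a nitrogen on an aromatic ring also counts, since propyl in place of isopropyl came with an at least 6.3-fold higher number from compound 2 to compound 3 (0.80 log units; beyond the scatter). On this read-out, the higher number stands for lower toxicity in this test, and the two chains have the same heavy atoms, so the rearrangement from isopropylamino to propylamino is the whole difference between the two compounds. The value of compound 3 is a limit of the assay and not a number, so the step gives only a lower bound on the size of the change: the limit of > 263000 nM in this assay, at which 1 of the 3 values shown sits.

The compounds shown do not tell whether a shorter chain such as ethyl, a longer chain such as butyl, or a ring such as cyclopropyl on this nitrogen would follow propyl or isopropyl. They also leave open whether propyl would bring a similar step on the core of compound 1, which carries a second bromo, and why two chains of the same size part so clearly here.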